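Trimming a Pyridine Ring to a Methyl Group

The source may hold more compounds than are shown below. What is called first, only, known or untested is meant among the compounds shown, and "the series" means these compounds.

Of the compounds shown here, three with a shared five-membered core have been tested in a functional assay on the whole organism (strain CF-1) for inhibition, with Mus musculus as the target; on this read-out lower numbers stand for an effect already at smaller amounts and higher numbers for an effect only at larger amounts of compound. Compound 1 `Cc1nnc(CN)n1-c1ccc(Cl)cc1C(O)c1ccccc1` gives 1.6 mg/kg in this assay. Compound 2 `Cc1nnc(CN2CCCC2)n1-c1ccc(Cl)cc1C(=O)c1ccccc1` gives 0.4 mg/kg in this assay. Compound 3 `CN(C)Cc1nnc(-c2ccncc2)n1-c1ccc(Cl)cc1C(=O)c1ccccc1Cl` gives 11 mg/kg in this assay, which is the highest number of the three; its nearest neighbour is compound 1, and the gap to it is beyond the usual scatter, while the gap to compound 2 is wider still.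

Compound 4 `Cc1nnc(CN(C)C)n1-c1ccc(Cl)cc1C(=O)c1ccccc1Cl` has not yet been measured. It differs from compound 3 in one place: methyl in place of pyridin-4-yl on an aromatic carbon. The group that enters, a methyl, is the same group that compounds 1 and 2 carry at that ring carbon, and both of those compounds sit well below compound 3 in this assay.

Because compound 1 gives 1.6 mg/kg and compound 2 gives 0.4 mg/kg with a methyl at that position, compound 4 is expected to move to a clearly lower number, a step of a 7.3-fold lower number from compound 3 to compound 4 (0.87 log units; beyond the scatter) beyond the scatter. The estimate for compound 4 in this assay is 1.5 mg/kg, with a likely range from 0.4 mg/kg to 6 mg/kg.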

Compound 4, dose for half-maximal effect: 0.14 mg/kg
Estimate against measurement, compound 4: 11-fold (1.03 log units) above; measured number below the stated range.
By their numbers in this assay, from the lowest: compound 4; then compound 2; then compound 1; then compound 3.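

Within this assay, replacing pyridin-4-yl with methyl on this aromatic carbon gives a 79-fold lower number from compound 3 to compound 4 (1.90 log units; beyond the scatter) and changes nothing else in the molecule. Among the compounds shown here, this is the first direct reading of this position, as the earlier compounds differ from one another in several places at once and could not isolate the contribution of this group. It shows that, with the rest of compound 3 held fixed, the whole six-membered aromatic ring and its hydrogen-bond acceptor can go from this carbon between two ring nitrogen atoms, leaving a single carbon, and a far smaller dose then gives the half-maximal effect, although nothing available explains why the step is so large.

From the compounds shown here alone, it remains open whether the step goes with losing the ring or only its nitrogen, which a phenyl group at this carbon would help separate, while an ethyl group or a plain hydrogen would show how the number responds to other small groups. Also open, going by these compounds, is whether the same swap gives a step of similar size when a diethylamino group replaces the dimethylamino group on the side chain.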